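The source may hold more compounds than are shown below. What is called first, only, known or untested is meant among the compounds shown, and "the series" means these compounds.

Measured compounds:
compound 1 `Cc1cc(=O)n(-c2cccc(F)c2)nc1C(=O)Nc1ccc(Oc2ncnc3ccsc23)c(F)c1` gives 5220 nM in a functional assay on A549 cells (Homo sapiens) for cytotoxicity, read by MTT assay, with a stated time of 72 h; on this read-out lower numbers stand for stronger inhibition and higher numbers for weaker inhibition
compound 2 `Cc1cc(=O)n(-c2ccc(F)cc2)nc1C(=O)Nc1ccc(Oc2ncnc3ccsc23)c(F)c1` gives 580 nM in this assay

Compound 2 stands at the lowest of the two numbers in this assay. Within the data shown here, its only measured neighbour is compound 1, and the step of a 9.0-fold lower number from compound 1 to compound 2 (0.95 log units; beyond the scatter) shows that moving the fluoro on the phenyl attached to the aromatic nitrogen from the 3-position to the 4-position brings a clearly lower number.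

Compound 3 `Cc1cc(=O)n(-c2ccc(F)c(F)c2)nc1C(=O)Nc1ccc(Oc2ncnc3ccsc23)c(F)c1` differs from compound 2 by fluoro in place of hydrogen on an aromatic carbon. It keeps the 4-fluoro that compound 2 carries and adds a second fluoro at the place where compound 1 had its only one. Among the measured compounds shown here, the single step that bears on this change is a 9.0-fold lower number from compound 1 to compound 2 (0.95 log units; beyond the scatter), which speaks against a fluoro at the 3-position when it stands alone; no measured pair shows what happens when both fluoro groups are present together. Compound 3 is therefore expected to keep the favourable 4-fluoro and to sit near compound 2, with the added fluoro more likely to raise the number somewhat than to lower it, by about a 1.7-fold higher number from compound 2 to compound 3 (0.24 log units; within the scatter). Compound 3 is estimated at 1000 nM in this assay, within the range 300 nM to 3500 nM.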

Compound 3, half-maximal inhibitory concentration: 4590 nM
Estimate against measurement, compound 3: 4.6-fold (0.66 log units) below, and the stated range ends below it.
By their numbers in this assay, from the lowest: compound 2; then compounds 3 and 1 (each within the scatter of the next).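

Adding a second fluoro to the 4-fluorophenyl of compound 2 gives up the low number, with a 7.9-fold higher number from compound 2 to compound 3 (0.90 log units; beyond the scatter) in this assay, so the 3,4-difluorophenyl does not inherit the standing of the 4-fluorophenyl. Read from the other side, adding a fluoro to the phenyl of compound 1 leaves the result within the scatter, at a 1.1-fold lower number from compound 1 to compound 3 (0.06 log units; within the scatter), which means that among these three compounds only the 4-fluorophenyl without the second fluoro reaches the low number. Nothing available gives a reason for this behaviour.

The compounds leave open whether the low number belongs to fluoro specifically, since a plain phenyl, a 4-chlorophenyl and a 4-methoxyphenyl do not appear among them. They also leave open how a larger or charged group on this phenyl, such as an amine or a carboxylic acid, would fare, and whether the sharp sensitivity seen here holds when the rest of the shared core is changed.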